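Notes on the side-chain step to compound 4

A few compounds are considered here, and "the series" means these few. Any claim that something is new, unique, unknown or untested is made for them only; others in the source may bear on it.

In a functional assay on HCC827 cells (Homo sapiens) for antiproliferative activity, read by MTT assay, with a stated time of 72 h (on this read-out higher numbers stand for weaker inhibition and lower numbers for stronger inhibition), compound 1 `CN1CCN(c2ccc(Nc3ncc4nc(Sc5ccccc5)n(C5CCCC5)c4n3)cc2)CC1` gives 51.2 nM. Compound 2 `CN(C)C1CCN(c2ccc(Nc3ncc4nc([S+]([O-])c5ccccc5)n(C5CCOCC5)c4n3)cc2)CC1` gives 1290 nM. Compound 3 `CN1CCC(Oc2ccc(Nc3ncc4nc([S+]([O-])c5ccccc5)n(C5CCOCC5)c4n3)cc2)CC1` gives 853 nM, which lies within the scatter of compound 2 and well above the number for compound 1. Compound 4 `CN(C)CCN(C)c1ccc(Nc2ncc3nc([S+]([O-])c4ccccc4)n(C4CCOCC4)c3n2)cc1` differs from compound 3 as follows: (2-(dimethylamino)ethyl)(methyl)amino in place of (1-methylpiperidin-4-yl)oxy on an aromatic carbon. In short, (2-(dimethylamino)ethyl)(methyl)amino stands in place of (1-methylpiperidin-4-yl)oxy on an aromatic carbon. Among the measured compounds shown here, one measured step bears on this, also an exchange of the group on an aromatic carbon: a 1.5-fold lower number from compound 2 to compound 3 (0.18 log units; within the scatter). On that evidence, no step beyond the scatter is expected in this assay. The expected outcome is a 1.1-fold higher number from compound 3 to compound 4 (0.02 log units; within the scatter). The estimate for compound 4 is 900 nM, with an expected range of 420 nM to 1900 nM.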

Compound 4, half-maximal inhibitory concentration: 1330 nM
Compound 4: the middle estimate sits 1.5-fold (0.17 log units) below what was measured; the range from low to high includes it.
By their numbers in this assay, from the lowest: compound 1; then compounds 3, 2 and 4 (each within the scatter of the next).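

In this assay, the open-chain (2-(dimethylamino)ethyl)(methyl)amino group on this aromatic carbon reads alike with both ring-bearing side chains (a 1.6-fold higher number from compound 3 to compound 4 (0.19 log units; within the scatter)) (a 1.0-fold higher number from compound 2 to compound 4 (0.01 log units; within the scatter)). At this position, then, the ring of the leaving group is not needed to hold the number within the scatter among compounds 2, 3 and 4. Nothing measured here accounts for this. Open, from the compounds shown here alone, is whether a shorter group, such as a plain dimethylamino, would read alike. Also open, going by these compounds, is whether a carboxylic acid at the chain end would.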